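Methoxy in Place of Fluoro: Expected Acid Dissociation

The source may report more compounds than this note shows. Statements on the series, on what has been measured and on what is new or still open speak of the compounds shown alone.

Compound 1 `Cc1ncc([N+](=O)[O-])n1CC(O)Cn1cc(C(=O)O)c(=O)c2cc(F)ccc21`: 5.18
Compound 2 `Cc1ncc([N+](=O)[O-])n1CC(O)Cn1cc(C(=O)O)c(=O)c2cc(F)cc(F)c21`: 5.33
Compound 3 `Cc1ncc([N+](=O)[O-])n1CC(O)Cn1cc(C(=O)O)c(=O)c2cc(F)c(Cl)cc21`: 5.15

In a physicochemical assay for acid dissociation, compound 1 gives 5.18, the second highest of the three numbers, with compound 3 nearest at 5.15 and compound 2 furthest at 5.33, both within the scatter of it. The two measured steps, a number 0.15 log units higher from compound 1 to compound 2 (within the scatter) and a number 0.03 log units lower from compound 1 to compound 3 (within the scatter), add a halogen to the shared core and change nothing beyond the scatter. Compound 4 `COc1ccc2c(c1)c(=O)c(C(=O)O)cn2CC(O)Cn1c([N+](=O)[O-])cnc1C` differs from compound 1 by methoxy in place of fluoro on an aromatic carbon. For the measured compounds named here, no measured step swaps fluoro for methoxy, so the halogen steps bear only loosely on it; since both stayed within the scatter, compound 4 is expected to move little, a number 0.17 log units higher from compound 1 to compound 4 (within the scatter). Compound 4 is therefore estimated at 5.35, between 5.05 and 5.65.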

Compound 4, acid dissociation constant: 5.72
Compound 4: the middle estimate sits 0.37 log units below what was measured, outside the stated range (above it).
By their numbers in this assay, from the lowest: compounds 3, 1 and 2 (each within the scatter of the next); then compound 4.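

In this assay, methoxy in place of fluoro gives a number 0.54 log units higher from compound 1 to compound 4 (beyond the scatter), the only step shown that passes the scatter. Neither halogen step did so, and this one replaces the fluoro of the shared core instead of adding to it, so the number can shift with what stands at this position. Nothing shown gives a reason for the shift. As far as these compounds go, it remains open whether the shift is particular to methoxy or would also appear with an amine or an ethoxy group in the same place.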